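The compounds below may be only part of what the source reports. "The series", "measured", "known", "first", "only" and "open" are said of these compounds alone.

Three compounds, all built on the same core carrying two amino groups, have been measured: compound 1 `Nc1nc(N)c2nc(Nc3cc(F)c(F)c(F)c3)ccc2n1`, compound 2 `Nc1nc(N)c2nc(Nc3ccc(OC(F)(F)F)cc3)ccc2n1` and compound 3 `CN(c1ccccc1)c1ccc2nc(N)nc(N)c2n1`. In an ADME assay on isolated protein for inhibition of Dihydrofolate reductase (Homo sapiens), using NADPH (on this read-out lower numbers stand for stronger inhibition and higher numbers for weaker inhibition), compound 1 gives 1810 nM, compound 2 gives 4130 nM and compound 3 gives 942 nM. Compound 3 thus shows the lowest of the three numbers; its gap to compound 1 is within the usual scatter, while its gap to compound 2 is beyond it, so compound 3 can only be placed below compound 2 with confidence.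

The next compound, compound 4 `CC(C)N(c1ccccc1)c1ccc2nc(N)nc(N)c2n1`, keeps everything of compound 3 except one group: isopropyl in place of methyl on a nitrogen on an aromatic ring. Going by the values given here, no measured pair shows a change of this kind, so the expectation rests on the value of compound 3 in this assay alone. The step of a 1.2-fold higher number from compound 3 to compound 4 (0.07 log units; within the scatter) is expected to be small and without a clear direction, most likely within the scatter. Compound 4 is estimated at 1100 nM, within a range from 400 nM to 3000 nM.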

Compound 4, half-maximal inhibitory concentration: 1370 nM
Beside the measured number, compound 4's estimate is 1.2-fold (0.10 log units) below it; low and high end bracket the measured number.
By their numbers in this assay, from the lowest: compounds 3, 4 and 1 (each within the scatter of the next); then compound 2.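

In this assay, putting isopropyl in place of methyl on a nitrogen on an aromatic ring gives a 1.5-fold higher number from compound 3 to compound 4 (0.16 log units; within the scatter), so the two compounds cannot be told apart. Going by these compounds alone, this is the first pair here that differs in one place, and it gives the first direct reading of this position: going from 1 heavy atom to 3 heavy atoms on this nitrogen brings no change that stands clear of the scatter. Nothing measured here speaks to why the number holds.

One pair cannot show how far this holds, so a longer chain such as butyl, a cyclohexyl ring, or a chain ending in an amine or a carboxylic acid might behave differently. From the compounds shown here alone, it also remains open whether the same swap would give a similar step with other groups on the aromatic ring.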